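Pyrazolyl in Place of Allyl on the Amide Nitrogen

The source may report more compounds than this note shows. Statements on the series, on what has been measured and on what is new or still open speak of the compounds shown alone.

Measured compounds:
compound 1, `Cc1ccc(OCC(=O)N(Cc2cccs2)C(C)C)cc1`: 70 nM
compound 2, `C=CCN(Cc1cccs1)C(=O)COc1ccc(C)cc1`: 20 nM

Of the compounds shown here, two have been measured in an assay on HEK293 cells for agonist activity at transient receptor potential cation channel subfamily M member 8 (Homo sapiens), read by fluorescence and calcium flux, with a stated time of 15 min; on this read-out higher numbers stand for an effect only at larger amounts of compound and lower numbers for an effect already at smaller amounts. Compound 1 gives 70 nM, and compound 2 gives 20 nM. Among the measured compounds shown here, the one step between them, a 3.5-fold lower number from compound 1 to compound 2 (0.54 log units; beyond the scatter), replaces isopropyl with allyl on the amide-type nitrogen, and it moved the number beyond the scatter. On the numbers shown, compound 2 therefore stands lowest of the two.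

The next compound, compound 3 `Cc1ccc(OCC(=O)N(Cc2cccs2)c2c(C)n[nH]c2C)cc1`, changes the same nitrogen again: 3,5-dimethyl-1H-pyrazol-4-yl in place of allyl on an amide-type nitrogen. For the measured compounds named here, the only measured step concerns a small saturated group giving way to a small unsaturated one on this nitrogen; no step introduces an aromatic ring with a donor and an acceptor there, so the change from compound 2 to compound 3 is not covered directly. Going by the values given here, since the one known step on this nitrogen was modest, and the new group is much larger, a step of some size is expected, with the direction uncertain and a higher number judged somewhat more likely. Compound 3 is accordingly expected to give 60 nM, with a range of 15 nM to 300 nM, which corresponds to an estimated step of a 3.0-fold higher number from compound 2 to compound 3 (0.48 log units; beyond the scatter).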

Compound 3, half-maximal effective concentration: 0.3 nM
The estimate for compound 3 lay 200-fold (2.30 log units) above the measured number; measured number below the stated range.
By their numbers in this assay, from the lowest: compound 3; then compound 2; then compound 1.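

In this assay, the amide-type nitrogen proves far more responsive than the earlier pair could show: the change from isopropyl to allyl gave only a 3.5-fold lower number from compound 1 to compound 2 (0.54 log units; beyond the scatter), whereas the pyrazole brings a 67-fold lower number from compound 2 to compound 3 (1.82 log units; beyond the scatter) and, measured against the isopropyl compound, a 230-fold lower number from compound 1 to compound 3 (2.37 log units; beyond the scatter). The position thus accepts much more than a small open group, since 3,5-dimethyl-1H-pyrazol-4-yl, with its 7 heavy atoms, its five-membered aromatic ring and its hydrogen-bond donor and acceptor, gives the lowest number of the three compounds. No measurement at hand accounts for a step of this size.

The entering group differs from allyl in several features at once, so the compounds shown do not separate the contribution of the aromatic ring from that of its two methyl groups or its ring hydrogen. As far as these compounds go, an unsubstituted 1H-pyrazol-4-yl, a phenyl or a 1,3,5-trimethylpyrazol-4-yl on the same nitrogen would bear on each of these, and how far the step depends on the rest of the shared core also remains open.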